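The source may report more compounds than this note shows. Statements on the series, on what has been measured and on what is new or still open speak of the compounds shown alone.

In an ADME assay on MDBK cells (Bos taurus) for cytotoxicity (a lower number here means that less compound is tolerated, a higher number that more compound is tolerated), three compounds that share one core have been measured so far. Compound 1 `Fc1cccc(F)c1Cn1ccc2nc(-c3ccccc3)nc-2c1` gives > 100000 nM, which is a limit of the assay and not a number. Compound 2 `COc1cccc(Cn2ccc3nc(-c4ccccc4)nc-3c2)c1` gives > 100000 nM, again a limit. Compound 3 `Brc1ccccc1Cn1ccc2nc(-c3ccccc3)nc-2c1` gives > 100000 nM, also a limit. For the measured compounds named here, compound 3 therefore has no exact value, and the whole series so far rests on (the limit of > 100000 nM in this assay, at which 3 of the 3 values shown sit).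

The next compound is compound 4 `Clc1ccc(Cn2ccc3nc(-c4ccccc4)nc-3c2)cc1Cl`, not yet measured. It differs from compound 3 in one place, with 3,4-dichlorophenyl in place of 2-bromophenyl on a saturated chain carbon bound to an aromatic nitrogen.

The measured steps at this same place are a step that the two limits leave unreadable from compound 1 to compound 2, a step that the two limits leave unreadable from compound 1 to compound 3 and a step that the two limits leave unreadable from compound 2 to compound 3. None of them has a readable size, so no step beyond the usual scatter is expected in this assay, and no direction can be given. The expected change is a number no higher from compound 3 to compound 4 (the limit leaves the size open). For compound 4 the estimated value is 100000 nM, with an expected range from 50000 nM to 200000 nM.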

Compound 4, half-maximal cytotoxic concentration: 71000 nM
Beside the measured number, compound 4's estimate is 1.4-fold (0.15 log units) above it; low and high end bracket the measured number.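

In this assay, for the compounds shown here, compound 4 is the first compound with a readable number, so this place on a saturated chain carbon bound to an aromatic nitrogen now has one exact value to set against the limits. Swapping in 3,4-dichlorophenyl gives an at least 1.4-fold lower number from compound 3 to compound 4 (0.14 log units; that floor lies within the scatter) and an at least 1.4-fold lower number from compound 2 to compound 4 (0.14 log units; that floor lies within the scatter) and an at least 1.4-fold lower number from compound 1 to compound 4 (0.14 log units; that floor lies within the scatter), and each of these floors lies within the scatter, so none of them shows a real drop on its own. The steps among the three earlier compounds still cannot be read, and most of the series still rests on one limit: (the limit of > 100000 nM in this assay, at which 3 of the 4 values shown sit).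

On these data alone, how far the number truly falls from those limits to compound 4 remains open. So does the effect of a group of another kind at this place, such as an amine or a carboxylic acid.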